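Swapping Acetoxy for Chloro on a Pyrimidinedione Side Chain

The source may hold more compounds than are shown below. What is called first, only, known or untested is meant among the compounds shown, and "the series" means these compounds.

Measured so far:
Compound 1 `CC(=O)OCCc1c(C)[nH]c(=O)[nH]c1=O` — > 100000 nM
Compound 2 `COc1nc(Cl)nc(C)c1CCOC(C)=O` — > 100000 nM

Compound 1 was tested in a functional assay on MCF7 cells (Homo sapiens) for antiproliferative activity, read by MTT assay, with a stated time of 24 h; on this read-out lower numbers stand for stronger inhibition and higher numbers for weaker inhibition. In this assay compound 1 gives > 100000 nM, which is a limit of the assay and not a number. Compound 2 is also at a limit, giving > 100000 nM in this assay. Both values therefore sit at the limit of > 100000 nM in this assay, at which 2 of the 2 values shown sit, so no ordering between compound 1 and compound 2 can be read from them.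

Compound 3 `Cc1[nH]c(=O)[nH]c(=O)c1CCCl` differs from compound 1 in one place: chloro in place of acetoxy on a saturated chain carbon, two bonds along the chain from an aromatic carbon. No measured step of this kind exists here, so the size of its effect rests on nothing shown. Because compound 1 sits at the limit of > 100000 nM in this assay, at which 2 of the 2 values shown sit, a step from compound 1 to compound 3 of a number no higher from compound 1 to compound 3 (the limit leaves the size open) is expected, most likely ending again at a limit. Compound 3 is estimated at 100000 nM, with a range from 20000 nM to 300000 nM.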

Compound 3, half-maximal inhibitory concentration: > 100000 nM
Compound 3: only a limit was reported; the forecaster's own chance of this, stated with the estimate: 80%; the middle value lies on the limit itself.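

In this assay compound 3 gives > 100000 nM, which is a limit of the assay and not a number. Compound 1 also sits at a limit, so no step from compound 1 to compound 3 can be read: the limit of > 100000 nM in this assay, at which 3 of the 3 values shown sit.

The compounds shown leave open whether chloro and acetoxy on this chain differ in effect at all.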